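A few compounds are considered here, and "the series" means these few. Any claim that something is new, unique, unknown or untested is made for them only; others in the source may bear on it.

Compound 1 `CC1=NN(c2ccccc2)C(=O)C12C=CC(=O)C=C2c1ccccc1`: in a functional assay on A549 cells (Homo sapiens) for antiproliferative activity, read by CCK-8 assay, with a stated time of 72 h (a lower number here means a stronger inhibitor, a higher number a weaker inhibitor), compound 1 gives 16500 nM.
Compound 2 `CC1=NN(c2ccc(C)cc2)C(=O)C12C=CC(=O)C=C2c1ccccc1`: in this assay compound 2 gives 46300 nM.
Compound 3 `CC1=NN(c2ccc(Cl)cc2)C(=O)C12C=CC(=O)C=C2c1ccccc1`: in this assay compound 3 reaches only the limit > 100000 nM, which is the limit of > 100000 nM in this assay, at which 1 of the 3 values shown sits.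

Compound 1 holds the lowest of the measured numbers; compound 2 lies higher by a 2.8-fold higher number from compound 1 to compound 2 (0.45 log units; beyond the scatter), and compound 3 higher still, by an at least 6.0-fold higher number from compound 1 to compound 3 (0.78 log units; beyond the scatter) and an at least 2.1-fold higher number from compound 2 to compound 3 (0.33 log units; beyond the scatter). Compound 4 `CC1=NN(c2ccccc2)C(=O)C12C=CC(=O)C=C2c1cccc(C)c1` differs from compound 1 by methyl in place of hydrogen on an aromatic carbon. Among the measured compounds shown here, the only measured methyl step, a 2.8-fold higher number from compound 1 to compound 2 (0.45 log units; beyond the scatter), is the nearest comparison, though the methyl there does not enter at the same place; the chloro steps bear on this change less. The expectation for compound 4 in this assay is therefore a small move toward a higher number, a 1.3-fold higher number from compound 1 to compound 4 (0.12 log units; within the scatter), close to the scatter. Compound 4 is estimated at 22000 nM, within a range from 8000 nM to 65000 nM.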

Compound 4, half-maximal inhibitory concentration: 16500 nM
Estimate against measurement, compound 4: 1.3-fold (0.12 log units) above; the range from low to high includes it.
By their numbers in this assay, from the lowest: compounds 1 and 4 (each within the scatter of the next); then compound 2. At a limit, above all of these: compound 3.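

The change from phenyl to 3-methylphenyl gives no change at the digits printed from compound 1 to compound 4 (within the scatter) in this assay, so this aromatic carbon accepts a methyl without a move beyond the scatter. The same replacement of hydrogen by methyl at another place gives a 2.8-fold higher number from compound 1 to compound 2 (0.45 log units; beyond the scatter), so across these compounds the outcome of this change depends on where the methyl enters. No measured property available here accounts for that difference. On these data alone, it remains open whether this position tolerates groups other than methyl. An amine, a carboxylic acid or a longer chain at this carbon would test that.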